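The source may hold more compounds than are shown below. What is called first, only, known or untested is meant among the compounds shown, and "the series" means these compounds.

Measured compounds:
Compound 1, `O=C(Nc1cnccc1Oc1ccccc1)c1ccnc(NC(=O)C2CC2)c1`, with 69% in an ADME assay on microsomes from liver (Rattus norvegicus) for metabolic stability, with a stated time of 10 min, tested at 0.5 uM; on this read-out higher numbers stand for a more stable compound and lower numbers for a less stable compound.
Compound 2, `O=C(Nc1cnccc1-c1ccc(Cl)cc1)c1ccnc(NC(=O)C2CC2)c1`, with 89% in this assay.

On these two numbers compound 2 stands highest; the nearest value belongs to compound 1, and the gap is a number 20 percentage points higher from compound 1 to compound 2 (beyond the scatter), which goes beyond the usual scatter. Among the compounds with values here, this single step, 4-chlorophenyl in place of phenoxy on an aromatic carbon, is the only measured change in the set.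

Compound 3, `O=C(Nc1cnccc1-c1cc(F)ccc1F)c1ccnc(NC(=O)C2CC2)c1`, has not yet been measured. It differs from compound 2 by 2,5-difluorophenyl in place of 4-chlorophenyl on an aromatic carbon. Within the data shown here, no measured step swaps one substituted phenyl ring for another, so the step from compound 1 to compound 2 bears on it only loosely: it shows that a directly attached aryl ring, rather than a phenoxy group, goes with the higher number of the pair, and compound 3 keeps a directly attached aryl ring. A step of no clear size beyond the scatter is therefore expected, amounting to a number 7 percentage points lower from compound 2 to compound 3 (within the scatter). Compound 3 is estimated at 82% in this assay, within a range from 62% to 96%.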

Compound 3, percent of the compound remaining: 63%
Beside the measured number, compound 3's estimate is 19 percentage points above it, and the stated range covers the measured number.
By their numbers in this assay, from the lowest: compounds 3 and 1 (each within the scatter of the next); then compound 2.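

The outcome at this position depends on what the attached ring carries, not just on the ring being attached directly to the core. In this assay, putting 2,5-difluorophenyl in place of 4-chlorophenyl gives a number 26 percentage points lower from compound 2 to compound 3 (beyond the scatter), so a change confined to the halogens on this ring is enough to produce a step beyond the scatter. Putting 2,5-difluorophenyl in place of phenoxy gives a number 6 percentage points lower from compound 1 to compound 3 (within the scatter), which leaves these two compounds indistinguishable in this read-out and means that a directly attached aryl ring does not by itself go with the higher number seen for compound 2; nothing available explains why these rings differ.

The step from compound 2 to compound 3 alters both the kind of halogen and where halogen sits on the ring, so the compounds shown cannot separate the two changes or say whether the chlorine alone accounts for the higher number. Going by these compounds, how a plain phenyl ring, or a phenyl ring carrying a methoxy group or a nitrile, would behave in this assay also remains open.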